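Amide chain extension and cell tolerance in the series

The source may hold more compounds than are shown below. What is called first, only, known or untested is meant among the compounds shown, and "the series" means these compounds.

Compound 3 `CNC(=O)c1c(NO)cc(-c2ccc(C)cc2)oc1=O` is characterised in an ADME assay on Huh-7 cells (Homo sapiens) for cytotoxicity, read by a luciferase reporter and WST assay, with a stated time of 3 days; a higher number here means that more compound is tolerated, a lower number that less compound is tolerated. In this assay compound 3 gives only a limit, > 20000 nM. Compound 1 `CNC(=O)c1c(NO)cc(-c2ccccc2)oc1=O` likewise gives only a limit in this assay, > 20000 nM. Compound 2 `CNC(=O)c1c(NO)cc(-c2ccc(Cl)cc2)oc1=O` also gives only a limit in this assay, > 20000 nM. The steps a step that the two limits leave unreadable from compound 1 to compound 2, a step that the two limits leave unreadable from compound 1 to compound 3 and a step that the two limits leave unreadable from compound 2 to compound 3 therefore cannot be sized; all three values sit at the limit of > 20000 nM in this assay, at which 3 of the 3 values shown sit.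

Compound 4 `Cc1ccc(-c2cc(NO)c(C(=O)NCCO)c(=O)o2)cc1` differs from compound 3 by hydroxymethyl in place of hydrogen on a saturated chain carbon bound to an amide-type nitrogen. The measured steps all concern the aromatic ring rather than the amide chain, and none of them yields a readable size, so they give no basis for expecting a shift beyond the scatter in this assay. The step is estimated as a step that the limit leaves unreadable from compound 3 to compound 4. Compound 4 is therefore expected to remain at the tolerance seen throughout the series, with an estimate in this assay of 25000 nM, ranging from 10000 nM to 80000 nM, most probably again reported only as a limit.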

Compound 4, half-maximal cytotoxic concentration: > 20000 nM
Compound 4: a limit, no number; the forecaster's own chance of this, stated with the estimate: 85%; the middle value lies beyond the limit too.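

Compound 3 and compound 4 both give only limits in this assay and the step between them cannot be read: the limit of > 20000 nM in this assay, at which 4 of the 4 values shown sit.

The compounds shown leave open the concentration at which compound 1, compound 2, compound 3 or compound 4 stops being tolerated in this assay and whether the aromatic or amide-chain changes alter it.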